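The source may hold more compounds than are shown below. What is called first, only, known or untested is meant among the compounds shown, and "the series" means these compounds.

Measured compounds:
- compound 1 `CCOC(=O)c1cc(-c2ccccc2)nn1CC(O)COc1ccccc1[N+](=O)[O-]` gives 30000 nM in a functional assay on A549 cells (Homo sapiens) for inhibition, read by MTT assay, with a stated time of 48 h; on this read-out lower numbers stand for stronger inhibition and higher numbers for weaker inhibition.
- compound 2 `CCOC(=O)c1cc(-c2ccccc2)nn1CC(O)COc1ccccc1OC` gives 58000 nM in this assay.
- compound 3 `CCOC(=O)c1cc(-c2ccc(OC)cc2)nn1CC(O)COc1ccccc1[N+](=O)[O-]` gives 45000 nM in this assay.

Compound 4 `CCOC(=O)c1cc(-c2ccc(OC)cc2)nn1CC(O)COc1ccccc1OC` has not been measured in this assay.

Compound 4 differs from compound 3 by methoxy in place of nitro on an aromatic carbon. The same change separates compound 2 from compound 1, (methoxy in place of nitro on an aromatic carbon), and there it made a 1.9-fold higher number from compound 1 to compound 2 (0.29 log units; within the scatter). The two cores on which the change is made differ by methoxy in place of hydrogen on an aromatic carbon, a difference that gave a 1.5-fold higher number from compound 1 to compound 3 (0.18 log units; within the scatter). The place of the change is described in the same words in both pairs, so it is taken as the same change on two closely related cores.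

All three measured numbers lie within the scatter of one another, so no ordering among them can be read. For compound 3 to compound 4 a step of about the same size as the earlier one is expected, a 1.9-fold higher number from compound 3 to compound 4 (0.28 log units; within the scatter), resting on compound 1 to compound 2 having shown a 1.9-fold higher number from compound 1 to compound 2 (0.29 log units; within the scatter). Compound 4 is therefore estimated at 85000 nM in this assay, with a likely range from 40000 nM to 180000 nM.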

Compound 4, half-maximal inhibitory concentration: 68000 nM
Beside the measured number, compound 4's estimate is 1.3-fold (0.10 log units) above it; measured number inside the range.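

In this assay, the change from 2-nitrophenoxy to 2-methoxyphenoxy gives a 1.5-fold higher number from compound 3 to compound 4 (0.18 log units; within the scatter), and this agrees with the same change on the other core: the same change on two cores in this assay, a 1.9-fold higher number (0.29 log units; within the scatter) from compound 1 to compound 2 and a 1.5-fold higher number (0.18 log units; within the scatter) from compound 3 to compound 4, 1.3-fold (0.11 log units) apart, within the scatter of two such steps

Methoxy in place of hydrogen on an aromatic carbon gives a 1.2-fold higher number from compound 2 to compound 4 (0.07 log units; within the scatter), and this likewise agrees with its earlier counterpart: the same change on two cores in this assay, a 1.5-fold higher number (0.18 log units; within the scatter) from compound 1 to compound 3 and a 1.2-fold higher number (0.07 log units; within the scatter) from compound 2 to compound 4, 1.3-fold (0.11 log units) apart, within the scatter of two such steps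

Both changes therefore carry between these two cores without a detectable difference, but every step lies within the scatter, so this agreement is between steps too small to read and does not show that either change has a real effect, or that the steps add up in a dependable way.

The compounds shown leave open whether an amine or a carboxylic acid at the place of the nitro or methoxy group would give a step beyond the scatter. They also leave open whether a longer chain in place of the ethyl group of the ester would do so, and whether any such step would carry from one core to the other.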